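This account rests on a few compounds, and the source may have more. Where it says the series, first, only, none or still open, it means among the compounds named here.

Compound 1 `COc1ccc(-c2cc(NNC(=O)Nc3cc(Cl)nc(Cl)c3)nc3c2cnn3C)cc1` gives 12300 nM here.
Compound 2 `COc1cc(NC(=O)NNc2cc(-c3ccccc3)c3cnn(C)c3n2)cc(Cl)n1` gives 31300 nM here.
Compound 3 `COc1ccc(-c2cc(NNC(=O)Nc3cc(Br)nc(Br)c3)nc3c2cnn3C)cc1` gives 45200 nM here.

These values come from a functional assay on HCT-116 cells (Homo sapiens) for cytotoxicity, read by MTT assay, with a stated time of 48 h, in the presence of a further agent that is not named here (on this read-out higher numbers stand for an effect only at larger amounts of compound and lower numbers for an effect already at smaller amounts), and compound 3 stands at the high end, within the usual scatter of compound 2. The next compound is compound 4 `COc1ccc(-c2cc(NNC(=O)Nc3cc(Cl)nc(OC)c3)nc3c2cnn3C)cc1` and its change from compound 3 is 2-chloro-6-methoxypyridin-4-yl in place of 2,6-dibromopyridin-4-yl on an amide-type nitrogen in which 2-chloro-6-methoxypyridin-4-yl replaces 2,6-dibromopyridin-4-yl on an amide-type nitrogen. Among the measured compounds shown here, the one measured step at this place is a 3.7-fold higher number from compound 1 to compound 3 (0.57 log units; beyond the scatter) and it is modest, but it involves a different group. Compound 2 at 31300 nM already carries the entering group, though it also differs from compound 4 elsewhere. Compound 1 at 12300 nM shows that a number well under that of compound 3 is possible. In this assay, for the measured compounds named here, no step clearly beyond the scatter is therefore expected, only a lean towards a lower number. The estimated change is a 1.7-fold lower number from compound 3 to compound 4 (0.24 log units; within the scatter) and it remains uncertain. Compound 4 is estimated at 26000 nM with 10000 nM to 60000 nM as its expected range.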

Compound 4, half-maximal effective concentration: 54200 nM
Beside the measured number, compound 4's estimate is 2.1-fold (0.32 log units) below it; the measured number falls inside the stated range.
By their numbers in this assay, from the lowest: compound 1; then compounds 2, 3 and 4 (each within the scatter of the next).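

In this assay the step with 2-chloro-6-methoxypyridin-4-yl in place of 2,6-dibromopyridin-4-yl on the amide-type nitrogen is a 1.2-fold higher number from compound 3 to compound 4 (0.08 log units; within the scatter) and so cannot be told from noise, which means this swap of two quite different sets of ring groups leaves the read-out where it was. Methoxy in place of hydrogen on an aromatic carbon gives a 1.7-fold higher number from compound 2 to compound 4 (0.24 log units; within the scatter) and is equally unreadable, whereas methoxy in place of chloro on an aromatic carbon gives a 4.4-fold higher number from compound 1 to compound 4 (0.64 log units; beyond the scatter) and marks compound 1, with its 2,6-dichloropyridin-4-yl, as the one clear outlier of the set. Nothing available here explains these differences.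

Going by these compounds, whether an amine or a carboxylic acid in place of the chloro of compound 4 would shift the number remains open. So does whether the lower number of compound 1 holds in other cell lines.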